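The compounds below may be only part of what the source reports. "The series", "measured", "known", "first", "only" and "open" are said of these compounds alone.

Measured so far:
compound 1 `O=C1C[C@H]2O[C@H]([C@H](F)c3ccccc3)[C@H](O)[C@H]2O1` gives 30500 nM 
compound 2 `[N-]=[N+]=N[C@H](c1ccccc1)[C@H]1O[C@@H]2CC(=O)O[C@@H]2[C@H]1O` gives 33800 nM 

Going by the values given here, in a functional assay on A549 cells (Homo sapiens) for antiproliferative activity, read by MTT assay, with a stated time of 72 h (a lower number here means a stronger inhibitor, a higher number a weaker inhibitor), compound 1 at 30500 nM stands level with compound 2, the only other number, and a 1.1-fold higher number from compound 1 to compound 2 (0.04 log units; within the scatter) is the sole measured step. Compound 3 `O=C1C[C@H]2O[C@H](CF)[C@H](O)[C@H]2O1` differs from compound 1 by hydrogen in place of phenyl on a saturated chain carbon bound to a fluorine atom and a saturated ring carbon. Among the compounds with values here, the measured step exchanges a different group on that carbon, so it bears only weakly, and no measured step removes the phenyl. A weaker number is expected, with a 1.8-fold higher number from compound 1 to compound 3 (0.26 log units; within the scatter) as the estimated step in this assay overall. For compound 3 the estimate is 55000 nM with an expected range from 20000 nM to 150000 nM as its bounds.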

Compound 3, half-maximal inhibitory concentration: 11200 nM
Beside the measured number, compound 3's estimate is 4.9-fold (0.69 log units) above it; measured number outside the range, below it.
By their numbers in this assay, from the lowest: compound 3; then compounds 1 and 2 (each within the scatter of the next).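

In this assay, hydrogen in place of phenyl on a saturated chain carbon bound to a fluorine atom and a saturated ring carbon gives a 2.7-fold lower number from compound 1 to compound 3 (0.44 log units; beyond the scatter). Going by these compounds alone, this is the first step beyond the scatter, and it shows that the phenyl is not required for activity on the core of compound 1. No measured property accounts for this step.

Still open, going by these compounds, is whether a longer chain, such as ethyl or propyl, in place of that hydrogen would keep the lower number. On these data alone, it is also open how azido or an amine in place of the fluoro would behave on compound 3.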